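Benzoyl in place of octylcarbonyl on the shared core

The source may hold more compounds than are shown below. What is called first, only, known or untested is meant among the compounds shown, and "the series" means these compounds.

For the measured compounds named here, compound 2 `CCCCCCCCC(=O)N1c2ccccc2CCC1C(=O)Nc1ccccc1O` stands at the lower of the two numbers measured so far in a functional assay on NUGC-3 cells (Homo sapiens) for cytotoxicity, read by sulforhodamine B assay, with a stated time of 72 h (on this read-out higher numbers stand for weaker inhibition of growth and lower numbers for stronger inhibition of growth), where compound 2 gives 31100 nM. Its nearest neighbour is compound 1 `O=C(Nc1ccccc1O)C1CCc2ccccc2N1C(=O)c1ccccc1Cl`, which in this assay gives 36800 nM; the step of a 1.2-fold lower number from compound 1 to compound 2 (0.07 log units; within the scatter) lies within the scatter, so the two are not separated by this read-out.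

Compound 3 `O=C(Nc1ccccc1O)C1CCc2ccccc2N1C(=O)c1ccccc1` differs from compound 2 by phenyl in place of octyl on a carbonyl carbon whose other neighbour is an amide-type nitrogen in a ring; cut one bond further out, the change reads octylcarbonyl to benzoyl.

Going by the values given here, only one measured step bears on this change, a 1.2-fold lower number from compound 1 to compound 2 (0.07 log units; within the scatter), which exchanged a 2-chlorophenyl for octyl at the same carbonyl carbon and stayed within the scatter. The phenyl of compound 3 is close in kind to the 2-chlorophenyl of compound 1, so no step beyond the scatter is expected in this assay in either direction.

Compound 3 is therefore estimated to give about 34000 nM, within a range from 15000 nM to 75000 nM. That estimate means an expected step of a 1.1-fold higher number from compound 2 to compound 3 (0.04 log units; within the scatter).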

Compound 3, concentration for 50% growth inhibition: 3780 nM
Compound 3: the middle estimate sits 9.0-fold (0.95 log units) above what was measured; the whole stated range lies above it.
By their numbers in this assay, from the lowest: compound 3; then compounds 2 and 1 (each within the scatter of the next).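

The carbonyl position on the ring nitrogen of the shared core is not indifferent to what it carries: in this assay the change from octyl to phenyl gives an 8.2-fold lower number from compound 2 to compound 3 (0.92 log units; beyond the scatter), whereas octyl and 2-chlorophenyl could not be separated by this read-out. The other new comparison, with hydrogen in place of chloro on an aromatic carbon, gives a 9.7-fold lower number from compound 1 to compound 3 (0.99 log units; beyond the scatter) and so shows that the benzoyl of compound 3 and the 2-chlorobenzoyl of compound 1 are far from interchangeable here, although the two differ in one place only. Compound 3 therefore stands apart from both earlier compounds, which remain level with each other, and no measurement shown here says what lies behind this separation.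

The compounds shown leave open whether the loss of growth inhibition follows chloro in particular or would also come with fluoro, methyl or methoxy on that aromatic carbon. They also leave open how a short acetyl or a longer chain on the same carbonyl carbon would compare with octyl and phenyl.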